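This account rests on a few compounds, and the source may have more. Where it says the series, first, only, none or still open, it means among the compounds named here.

In a functional assay on P388 cells (Mus musculus) for antiproliferative activity, read by colorimetric assay and MTT assay (a higher number here means a weaker inhibitor, a lower number a stronger inhibitor), compound 1 `COc1ccc(S(=O)(=O)Nc2cccc3cc[nH]c23)cc1` gives 1.1 ug/mL, compound 2 `COc1ccc(S(=O)(=O)Nc2ccc(Cl)c3cc[nH]c23)cc1` gives 1.1 ug/mL, and compound 3 `O=S(=O)(Nc1cccc2cc[nH]c12)c1ccc(Cl)cc1` gives 6 ug/mL, the highest number of the three. Compound 4 `O=S(=O)(Nc1cccc2c(Cl)c[nH]c12)c1ccc(Cl)cc1` differs from compound 3 by one change, chloro in place of hydrogen on an aromatic carbon. The closest guide is the same kind of swap made at another place on the shared core, which gave no change at the digits printed from compound 1 to compound 2 (within the scatter). The other measured step, a 5.5-fold higher number from compound 1 to compound 3 (0.74 log units; beyond the scatter), is a different swap and bears on this one only weakly. One earlier chloro step is thin evidence, so no step beyond the scatter is expected, but with wide uncertainty. The estimated step is a 1.5-fold lower number from compound 3 to compound 4 (0.18 log units; within the scatter). For compound 4 the expected value is 4 ug/mL, with an estimated range of 1 ug/mL to 12 ug/mL.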

Compound 4, half-maximal inhibitory concentration: 4.3 ug/mL
For compound 4 the middle estimate is 1.1-fold (0.03 log units) below the measured one; measured number inside the range.
By their numbers in this assay, from the lowest: compounds 1 and 2 (each within the scatter of the next); then compounds 4 and 3 (each within the scatter of the next).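

In this assay, chloro on this carbon of the five-membered aromatic ring, two ring bonds from the ring nitrogen, gives a 1.4-fold lower number from compound 3 to compound 4 (0.14 log units; within the scatter). This position therefore accepts a chlorine with no step beyond the scatter, at least on the core of compound 3. Chloro in place of hydrogen now reads alike at two places on two cores: the same change on two cores in this assay, no change at the digits printed (within the scatter) from compound 1 to compound 2 and a 1.4-fold lower number (0.14 log units; within the scatter) from compound 3 to compound 4, 1.4-fold (0.14 log units) apart, within the scatter of two such steps.

Going by these compounds, whether an amine or a carboxylic acid on this same carbon would also leave the number within the scatter remains open.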